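The source may hold more compounds than are shown below. What is called first, only, known or untested is meant among the compounds shown, and "the series" means these compounds.

Measured in a functional assay on MCF7 cells (Homo sapiens) for inhibition, read by sulforhodamine B assay; a lower number here means a stronger inhibitor, a higher number a weaker inhibitor:
compound 1 `O=C1C=C(N2CCC2)C(=O)c2c1nc1n2[C@H]2OC[C@@H](O)[C@H]2OC1`: > 16000 nM (a limit of the assay)
compound 2 `O=C1C(NC2CCCC2)=CC(=O)c2c1nc1n2[C@H]2OC[C@@H](O)[C@H]2OC1`: > 16000 nM (a limit of the assay)
compound 3 `CCc1ccc(NC2=CC(=O)c3nc4n(c3C2=O)[C@H]2OC[C@@H](O)[C@H]2OC4)cc1`: 960 nM

Compound 2 has no number, only a limit. It stands at the limit of > 16000 nM in this assay, at which 2 of the 3 values shown sit.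

The next compound to consider is compound 4 `O=C1C(N2CCCC2)=CC(=O)c2c1nc1n2[C@H]2OC[C@@H](O)[C@H]2OC1`. It carries pyrrolidin-1-yl in place of cyclopentylamino on a double-bonded ring carbon of a six-membered non-aromatic ring of carbon only, part of a fused or bridged system of four rings: pyrrolidin-1-yl in place of cyclopentylamino on a double-bonded ring carbon.

Within the data shown here, no measured step covers this exchange directly. The only one at hand, an at least 16-fold lower number from compound 1 to compound 3 (1.22 log units; beyond the scatter), is large, and it replaces azetidin-1-yl with (4-ethylphenyl)amino on a double-bonded ring carbon. Among these three compounds, only compound 3, at 960 nM, gives a number. Compound 4 does not carry the (4-ethylphenyl)amino group of compound 3, so that large step is not expected to carry over. Compound 1 remains at a limit, > 16000 nM, and its azetidin-1-yl group is the closest match to the entering pyrrolidin-1-yl.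

No step beyond the scatter is expected in this assay, and the expected change is a step that the limit leaves unreadable from compound 2 to compound 4. A report as a limit only is the likeliest outcome. Compound 4 is estimated at 20000 nM, with an expected range of 9000 nM to 45000 nM.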

Compound 4, half-maximal inhibitory concentration: > 16000 nM
Compound 4 was reported as a limit; the forecaster's own chance of this, stated with the estimate: 75%; the middle value is on the limit's open side.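

No new step can be read from compound 2 to compound 4 in this assay: both are reported only as limits of the assay, which leave the size of the exchange unreadable. Both sit at the same limit: the limit of > 16000 nM in this assay, at which 3 of the 4 values shown sit.

The compounds shown leave open whether cyclopentylamino and pyrrolidin-1-yl differ at all in this measurement.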